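The source may hold more compounds than are shown below. What is called first, only, known or untested is meant among the compounds shown, and "the series" means these compounds.

Measured compounds in a functional assay on MDA-MB-231 cells (Homo sapiens) for cytotoxicity, read by MTT assay, with a stated time of 72 h; a higher number here means a weaker inhibitor, a lower number a stronger inhibitor:
compound 1 `CCCCCCNc1nc(SCc2ccc(C(F)(F)F)cc2)nc2ccccc12` gives 20200 nM
compound 2 `Fc1ccc(Nc2nc(SCc3ccc(C(F)(F)F)cc3)nc3ccccc23)cc1` gives 15000 nM
compound 3 `O=[N+]([O-])c1ccc(Nc2nc(SCc3ccc(C(F)(F)F)cc3)nc3ccccc23)cc1` gives 8670 nM

Among these three, compound 3 has the lowest number in this assay. Its distance from compound 1 is real: a 2.3-fold lower number from compound 1 to compound 3 (0.37 log units; beyond the scatter). Its distance from compound 2 is not: a 1.7-fold lower number from compound 2 to compound 3 (0.24 log units; within the scatter), so compound 2 and compound 3 cannot be ordered against each other on these data. The step from compound 1 to compound 2, a 1.3-fold lower number from compound 1 to compound 2 (0.13 log units; within the scatter), likewise stays inside the scatter.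

Compound 4 `CCOc1ccc(Nc2nc(SCc3ccc(C(F)(F)F)cc3)nc3ccccc23)cc1` differs from compound 3 in one place: ethoxy in place of nitro on an aromatic carbon. Within the data shown here, the only measured step that touches this part of the molecule is the one from compound 2 to compound 3, where a change of the group on this same aromatic carbon moved the number by less than the scatter. Among the measured compounds shown here, nothing among the measured steps points to a large effect from swapping one group for another at this position, so in this assay no step beyond the scatter is expected, with at most a slight drift toward a higher number, a 1.4-fold higher number from compound 3 to compound 4 (0.14 log units; within the scatter). Compound 4 is therefore estimated at 12000 nM, within a range of 5000 nM to 30000 nM.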

Compound 4, half-maximal inhibitory concentration: 23000 nM
Estimate against measurement, compound 4: 1.9-fold (0.28 log units) below; the measured number falls inside the stated range.
By their numbers in this assay, from the lowest: compounds 3, 2, 1 and 4 (each within the scatter of the next, the first and the last beyond it).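

In this assay, among these compounds, the group on this aromatic carbon, para to a large group, now makes a readable difference: ethoxy in place of nitro gives a 2.7-fold higher number from compound 3 to compound 4 (0.42 log units; beyond the scatter) and is the first step at this position to pass the scatter, though it is modest. Ethoxy cannot be told from fluoro (a 1.5-fold higher number from compound 2 to compound 4 (0.19 log units; within the scatter)), and 4-ethoxyphenyl cannot be told from hexyl on the nitrogen (a 1.1-fold higher number from compound 1 to compound 4 (0.06 log units; within the scatter)), so among the groups on this carbon only nitro and ethoxy are separated. No measurement shown bears on why these two groups differ.

The compounds shown leave open whether an amine, a carboxylic acid or a longer alkoxy chain on this carbon would shift the number further in either direction. They also leave open whether nitro and ethoxy would differ in the same way on a changed core.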